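Cytotoxicity limit in the series: ethyl to isopropyl

The compounds below may be only part of what the source reports. "The series", "measured", "known", "first", "only" and "open" are said of these compounds alone.

Measured compounds, each value a limit in an ADME assay on PBMC cells (Homo sapiens) for cytotoxicity (a lower number here means that less compound is tolerated, a higher number that more compound is tolerated), and not a number:
- compound 1 `CC(C)c1c(Cc2ccccc2)n(COCc2ccccc2)c(=O)[nH]c1=O` gives > 10000 nM as a limit
- compound 2 `Cc1cc(C)cc(Cc2c(C(C)C)c(=O)[nH]c(=O)n2COCc2ccc(C(=O)/C=C(\O)C(=O)O)cc2)c1` gives > 10000 nM as a limit
- compound 3 `CCc1c(Cc2ccccc2)n(COCc2ccc(C(=O)/C=C(\O)C(=O)O)cc2)c(=O)[nH]c1=O` gives > 10000 nM as a limit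

Compound 3 stands at the limit of > 10000 nM in this assay, at which 3 of the 3 values shown sit, and has no number of its own. For the measured compounds named here, compound 4 `CC(C)c1c(Cc2ccccc2)n(COCc2ccc(C(=O)/C=C(\O)C(=O)O)cc2)c(=O)[nH]c1=O` differs from compound 3 by methyl in place of hydrogen on a saturated chain carbon bound to an aromatic carbon and a saturated chain carbon as its one change, methyl in place of hydrogen on a saturated chain carbon bound to an aromatic carbon and a saturated chain carbon, which reads as ethyl to isopropyl.

Going by the values given here, no two measured compounds differ in one place only, so the data hold no direct precedent for this change. A step beyond the scatter is not expected in either direction. Compound 2 also carries the isopropyl and gives > 10000 nM as a limit. The expected step is a step that the limit leaves unreadable from compound 3 to compound 4 and no larger. Compound 4 is expected at 15000 nM with an estimated range of 7000 nM to 50000 nM and will most likely be reported only as a limit.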

Compound 4, half-maximal cytotoxic concentration: > 10000 nM
Compound 4 ended at the assay's limit; the forecaster's own chance of this, stated with the estimate: 85%; the middle value is on the limit's open side.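

In this assay compound 4 gives > 10000 nM, a limit and not a number. No step to compound 4 from compound 1, compound 2 or compound 3 can be read: the limit of > 10000 nM in this assay, at which 4 of the 4 values shown sit.

The compounds shown leave open at what concentration any of them becomes cytotoxic, and whether ethyl to isopropyl alters that concentration.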